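The source may hold more compounds than are shown below. What is called first, only, known or untested is meant among the compounds shown, and "the series" means these compounds.

Measured so far in an assay on CHO cells for positive allosteric modulation of metabotropic glutamate receptor 5 (Homo sapiens), read by FLIPR; a higher number here means that more compound is needed for the effect, a lower number that less compound is needed:
- compound 1, `O=C(Nc1ccc(Cl)cc1CN1C(=O)c2ccccc2C1=O)c1ccccc1[N+](=O)[O-]`, gives 5700 nM
- compound 2, `O=C(Nc1ccc(Cl)cc1CN1C(=O)c2ccccc2C1=O)c1cncs1`, gives 1900 nM

Within the data shown here, compound 2 holds the lower of the two numbers in this assay; the only measured step, a 3.0-fold lower number from compound 1 to compound 2 (0.48 log units; beyond the scatter), separates it from compound 1, and that step is modest though beyond the scatter.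

The next compound is compound 3, `O=C(Nc1ccc(Cl)cc1CN1C(=O)c2ccccc2C1=O)c1ncccc1O`. It differs from compound 2 by 3-hydroxypyridin-2-yl in place of 1,3-thiazol-5-yl on a carbonyl carbon. Among the measured compounds shown here, the one step that bears on this change is the exchange of the aryl group on the same carbonyl carbon, a 3.0-fold lower number from compound 1 to compound 2 (0.48 log units; beyond the scatter), which was modest. For the measured compounds named here, no measured pair shows what a six-membered ring or a hydroxyl group in this position does, so the direction of the step from compound 2 to compound 3 is open. The working expectation is a step in this assay of about the same order as the one measured, or none beyond the scatter, with the number for compound 3 estimated at 1500 nM within a range of 500 nM to 5000 nM. This estimate corresponds to an expected 1.3-fold lower number from compound 2 to compound 3 (0.10 log units; within the scatter).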

Compound 3, half-maximal effective concentration: 260 nM
The estimate for compound 3 lay 5.8-fold (0.76 log units) above the measured number; measured number outside the range, below it.
By their numbers in this assay, from the lowest: compound 3; then compound 2; then compound 1.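

In this assay, among these compounds, the group on the carbonyl carbon has more influence than the earlier exchange indicated: 3-hydroxypyridin-2-yl in place of 1,3-thiazol-5-yl gives a 7.3-fold lower number from compound 2 to compound 3 (0.86 log units; beyond the scatter), and 3-hydroxypyridin-2-yl in place of 2-nitrophenyl gives a 22-fold lower number from compound 1 to compound 3 (1.34 log units; beyond the scatter), the only step printed as large. Ring size alone does not order these compounds, since compound 1 and compound 3 both carry a six-membered aromatic ring yet hold the highest and lowest numbers of the three, with the five-membered ring of compound 2 lying in the middle. Nothing available accounts for the lower number of compound 3.

The exchange to compound 3 alters the ring, its hetero atom and the hydroxyl group together, so the share of each remains unresolved. A plain pyridin-2-yl group, or a 3-methoxypyridin-2-yl or 3-aminopyridin-2-yl group on the same carbonyl carbon, would separate the contribution of the hydroxyl group from that of the ring.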